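Capping the phenol oxygen of compound 3 with phenylcarbamoyl

The source may hold more compounds than are shown below. What is called first, only, known or untested is meant among the compounds shown, and "the series" means these compounds.

Measured so far in a functional assay (trachea) with Rattus norvegicus as the target; a lower number here means a less potent compound, a higher number a more potent compound, by a factor of ten per unit of this negative logarithm:
compound 1 `CC(=O)c1ccc2c(c1)C(n1ccccc1=O)=CC(C)(C)O2` gives 6.65
compound 2 `Cc1ccc(C)n1-c1ccc2c(c1)C(n1ccccc1=O)=CC(C)(C)O2` gives 6.78
compound 3 `CC1(C)C=C(n2ccccc2=O)c2cc(O)ccc2O1` gives 5.31

Compound 3 stands lowest of the three numbers in this assay; its nearest neighbour is compound 1 and its furthest is compound 2, both beyond the scatter. Compounds 1 and 2 lie within the scatter of each other, so nothing separates them.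

Compound 4 `CC1(C)C=C(n2ccccc2=O)c2cc(OC(=O)Nc3ccccc3)ccc2O1` differs from compound 3 by phenylcarbamoyl in place of hydrogen on an oxygen on an aromatic ring. Going by the values given here, no measured step alters the hydrogen on this oxygen, so the bearing steps are those that exchange the hydroxy itself: a number 1.34 log units lower from compound 1 to compound 3 (beyond the scatter) and a number 1.47 log units lower from compound 2 to compound 3 (beyond the scatter). Read outward from compound 3, both say that a larger group in place of hydroxy on the aromatic carbon comes with a large rise, and the rise was of much the same size whichever group entered. Compound 4 keeps the oxygen and adds a large group onto it, so a rise is expected, though with less confidence than a direct exchange would carry. The step is estimated at a number 0.99 log units higher from compound 3 to compound 4 (beyond the scatter). Compound 4 is therefore estimated at 6.3, with a range from 5.5 to 7.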

Compound 4, logarithm of the reciprocal of the active concentration, log(1/C): 4.89
Compound 4: middle estimate off by 1.41 log units, on the high side; measured number below the stated range.
By their numbers in this assay, from the lowest: compound 4; then compound 3; then compounds 1 and 2 (each within the scatter of the next).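

Phenylcarbamoyl on the oxygen of compound 3 does not follow the direction set by the earlier exchanges at this aromatic carbon: in this assay the step is downward (a number 0.42 log units lower from compound 3 to compound 4 (beyond the scatter)). Size of the entering group alone therefore does not predict the number here, as acetyl in compound 1 and 2,5-dimethyl-1H-pyrrol-1-yl in compound 2 stand well above the hydroxy of compound 3, while the larger oxygen-linked group of compound 4 stands below it. The free hydroxy is thus not the floor of this position, and no supporting measurement bears on this result.

The compounds shown do not separate the contribution of the phenyl ring from that of the carbamoyl link or the retained oxygen. A methyl ether, an acetate ester or an aromatic amine at this place would address that question.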